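A Pyrazole Takes the Place of the Thiophene

This account rests on a few compounds, and the source may have more. Where it says the series, first, only, none or still open, it means among the compounds named here.

Of the compounds shown here, three sharing one core have been tested in a functional assay for activation of Alpha-1D adrenergic receptor (Homo sapiens), read by calcium flux; a higher number here means that more compound is needed for the effect, a lower number that less compound is needed. Compound 3 `c1csc(-c2ccccc2OCC2=NCCN2)c1` carries a thiophen-2-yl group and gives 15.9 nM in this assay. Compound 1 `c1cncc(-c2ccccc2OCC2=NCCN2)c1` carries a pyridin-3-yl group in the same place and gives 158 nM in this assay. For compound 2 `Cc1cccc(-c2ccccc2OCC2=NCCN2)n1` the record in this assay is < 100000 nM, which is the limit of < 100000 nM in this assay, at which 1 of the 3 values shown sits, rather than a number. Among the compounds with values here, of the two numbers, compound 3 has the lowest, and the single measured step is a 9.9-fold lower number from compound 1 to compound 3 (1.00 log units; beyond the scatter).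

Compound 4 `c1ccc(-c2cc[nH]n2)c(OCC2=NCCN2)c1` has not yet been measured. It differs from compound 3 by 1H-pyrazol-3-yl in place of thiophen-2-yl on an aromatic carbon. Within the data shown here, the only measured step that bears on this change is a 9.9-fold lower number from compound 1 to compound 3 (1.00 log units; beyond the scatter), where a sulfur-containing five-membered ring took the place of a nitrogen-containing six-membered ring and the number fell. Among the measured compounds shown here, the new change brings nitrogen back into the ring, together with a hydrogen-bond donor, so a move back toward a higher number is expected, though with no direct precedent its size is uncertain. Compound 4 is therefore expected to give 150 nM in this assay, within a range from 30 nM to 800 nM. That estimate corresponds to an expected step of a 9.4-fold higher number from compound 3 to compound 4 (0.97 log units; beyond the scatter).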

Compound 4, half-maximal effective concentration: < 100000 nM
Compound 4: only a limit was reported (the forecaster's own chance of this, stated with the estimate: 10%); the middle value is on the limit's open side.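

In this assay compound 4 gives < 100000 nM, which is a limit and not a number. The steps to compound 4 from compound 3 and from compound 1 therefore cannot be read. The compounds shown leave open what number lies behind that limit, and so how 1H-pyrazol-3-yl compares with thiophen-2-yl or pyridin-3-yl.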